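The compounds below may be only part of what the source reports. "The series", "measured", "known", "first", "only" and "open" are said of these compounds alone.

In the series examined here, growth inhibition of breast epithelial cells was followed in an ADME assay on MCF-10A cells (Homo sapiens) for cytotoxicity, read by sulforhodamine B assay, with a stated time of 48 h; on this read-out higher numbers stand for weaker inhibition of growth and lower numbers for stronger inhibition of growth. Compound 1, with the structure `CCN(CC)CN1C(=O)/C(=N\c2nc3ccc(C)cc3s2)c2ccccc21`, gives 20400 nM in this assay. Compound 2, with the structure `CCN(CC)CN1C(=O)/C(=N\c2nc3ccc(C)cc3s2)c2c(Br)cccc21`, gives 16100 nM. Compound 3, with the structure `CN(C)CN1C(=O)C(=O)c2c(Br)cccc21`, gives 67800 nM, the highest of the three numbers; it lies beyond the scatter from both compound 1 and compound 2. The cores of compound 2 and compound 3 differ in more than one place, and that difference is not broken down here.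

Between compound 2 and compound 1 a single change is made: hydrogen in place of bromo on an aromatic carbon. The step that accompanied it in this assay was a 1.3-fold higher number from compound 2 to compound 1 (0.10 log units; within the scatter), so the bromo group made no clear difference to growth inhibition in that pair.

Compound 4, with the structure `CN(C)CN1C(=O)C(=O)c2ccccc21`, has not yet been measured. Within the data shown here, it differs from compound 3 by hydrogen in place of bromo on an aromatic carbon, which is the same change, at the same kind of place, as the one from compound 2 to compound 1. Because a 1.3-fold higher number from compound 2 to compound 1 (0.10 log units; within the scatter) stayed within the scatter, the step from compound 3 to compound 4 is also expected to be small, a 1.2-fold higher number from compound 3 to compound 4 (0.07 log units; within the scatter). Compound 4 is therefore estimated at 80000 nM in this assay, with a plausible range from 35000 nM to 180000 nM; this rests on one earlier pair only, and a weakly inhibiting compound may also return only a limit.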

Compound 4, concentration for 50% growth inhibition: 150000 nM
Estimate against measurement, compound 4: 1.9-fold (0.27 log units) below, within the range that was stated.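

Replacing bromo with hydrogen on the core of compound 3 gave, in this assay, a 2.2-fold higher number from compound 3 to compound 4 (0.34 log units; beyond the scatter), a modest weakening of growth inhibition on this core. Set beside the earlier pair, the two steps are no further apart than two such steps can be by chance, so the change cannot be said to act differently on the two cores: the same change on two cores in this assay, a 1.3-fold higher number (0.10 log units; within the scatter) from compound 2 to compound 1 and a 2.2-fold higher number (0.34 log units; beyond the scatter) from compound 3 to compound 4, 1.7-fold (0.24 log units) apart, within the scatter of two such steps. Among these compounds, this does not show that the change has the same size on every core: it rests on only two pairs, one step lies within the scatter and the other beyond it, and neither pair says why swapping bromo for hydrogen moves the number at all.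

The compounds shown leave open whether another group on the same aromatic carbon, such as chloro, fluoro or methoxy, would give a number closer to that of bromo or of hydrogen in this assay. They also leave open what the amine on the ring nitrogen contributes, as dimethylamino and diethylamino appear here only alongside other differences, and a cyclic amine such as morpholine does not appear at all.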